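The source may report more compounds than this note shows. Statements on the series, on what has been measured and on what is new or still open speak of the compounds shown alone.

Working notes on the series, read in a functional assay on C6 cells (Rattus norvegicus) for inhibition, read by sulforhodamine B assay, with a stated time of 72 h; a higher number here means that more compound is needed for the effect, a lower number that less compound is needed. Compound 1 (`CCC(=O)Oc1cccc2ccc(/C=C/c3ccccc3[N+](=O)[O-])nc12`) gives 6300 nM, compound 2 (`O=C(/C=C/c1ccc([N+](=O)[O-])o1)c1ccc(I)cc1`) gives 2100 nM, and compound 3 (`CC(C)(C)c1ccc(C(=O)/C=C/c2ccc([N+](=O)[O-])o2)cc1`) gives 28600 nM. That last number is the highest of the three and lies beyond the scatter from both others.

The next structure is compound 4 (`O=C(/C=C/c1ccc([N+](=O)[O-])o1)c1ccc(C2CCCCC2)cc1`), with cyclohexyl in place of tert-butyl on an aromatic carbon, para to a large group: cyclohexyl in place of tert-butyl on an aromatic carbon. Going by the values given here, one measured step bears on this place: a 14-fold higher number from compound 2 to compound 3 (1.13 log units; beyond the scatter), a large step that came with tert-butyl in place of iodo. Among the compounds with values here, no measured pair compares tert-butyl with cyclohexyl, and the core of compound 1 differs, so compound 1 gives only a general sense of the range.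

Within the data shown here, the expectation rests on compound 3 standing at 28600 nM, the top of the numbers so far, with compound 2 at 2100 nM showing that this place can carry a much lower number. The step expected is moderate and toward a lower number, a 2.2-fold lower number from compound 3 to compound 4 (0.34 log units; beyond the scatter), although the evidence for its direction is thin. For compound 4 the estimated value is 13000 nM, with an expected range from 3500 nM to 40000 nM.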

Compound 4, half-maximal effective concentration: 5100 nM
The estimate for compound 4 lay 2.5-fold (0.41 log units) above the measured number; low and high end bracket the measured number.
By their numbers in this assay, from the lowest: compound 2; then compounds 4 and 1 (each within the scatter of the next); then compound 3.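

In this assay the place on an aromatic carbon, para to a large group, now carries three groups on the shared core, and cyclohexyl in place of tert-butyl gives a 5.6-fold lower number from compound 3 to compound 4 (0.75 log units; beyond the scatter) so a group of carbon only at this place need not bring the high number of compound 3. Iodo still gives the lowest number of the three, with a 2.4-fold higher number from compound 2 to compound 4 (0.39 log units; beyond the scatter) so cyclohexyl takes back part of a 14-fold higher number from compound 2 to compound 3 (1.13 log units; beyond the scatter) without reaching compound 2. No measurement at hand accounts for the difference between tert-butyl and cyclohexyl at this place, or for that between either of them and iodo.

The compounds shown leave open how an amine, a carboxylic acid or a longer chain at this place would stand against iodo and cyclohexyl. As far as these compounds go, compound 1 carries a different core, so steps between it and the other compounds cannot be read, and whether the order of iodo, cyclohexyl and tert-butyl would hold on that core also remains open.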